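The compounds below may be only part of what the source reports. "The series", "measured", "known", "first", "only" and "open" are said of these compounds alone.

Compound 1 `Cc1ccc(-c2cc(C(=O)NCCCCCCC(=O)NO)nn2-c2ccc(S(N)(=O)=O)cc2)cc1`: > 100000 nM
Compound 2 `COc1ccc2c(c1)c(CC(=O)O)c(C)n2Cc1ccc(-c2cn(CCCCCCC(=O)NO)nn2)cc1`: "not determined" (no result reported)
Compound 3 `COC(=O)Cc1c(C)n(Cc2ccc(-c3cn(CCCCCCCC(=O)NO)nn3)cc2)c2ccc(OC)cc12`: 5730 nM

Within the data shown here, in a toxicity assay on Vero cells (Chlorocebus sabaeus) for inhibition, read by MTT assay, with a stated time of 72 h (on this read-out lower numbers stand for stronger inhibition and higher numbers for weaker inhibition), compound 3 gives 5730 nM, the only actual number among the three. The entry for compound 1, > 100000 nM, is a limit of the assay and not a number. Compound 2 has no result.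

Compound 4 `COC(=O)Cc1c(C)n(Cc2ccc(-c3cn(CCCCCC(=O)NO)nn3)cc2)c2ccc(OC)cc12` keeps the structure of compound 3 but shortens the chain that ends in the hydroxycarbamoyl group: hydroxycarbamoyl in place of 2-(hydroxycarbamoyl)ethyl on a saturated chain carbon, five bonds along the chain from an aromatic nitrogen. Among the measured compounds shown here, no measured pair of compounds shows the effect of such a change. A modest shift toward weaker inhibition in this assay is therefore expected, estimated as a 1.6-fold higher number from compound 3 to compound 4 (0.20 log units; within the scatter). The estimated value for compound 4 is 9000 nM, within an expected range of 2500 nM to 35000 nM.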

Compound 4, half-maximal inhibitory concentration: 37800 nM
Compound 4: middle estimate off by 4.2-fold (0.62 log units), on the low side; measured number outside the range, above it.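

Replacing 2-(hydroxycarbamoyl)ethyl with hydroxycarbamoyl at this chain position gives, in this assay, a 6.6-fold higher number from compound 3 to compound 4 (0.82 log units; beyond the scatter). Within this pair, then, the length of the chain ending in the hydroxycarbamoyl group clearly affects the read-out, and the shorter chain gives the weaker inhibition. Compound 4 still gives a real number and not a limit of the assay: the limit of > 100000 nM in this assay, at which 1 of the 4 values shown sits.

This single pair cannot show whether the trend continues along a series of chain lengths. From the compounds shown here alone, how a longer chain, or a carboxylic acid in place of the hydroxycarbamoyl group, would shift the number stays open.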